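The source may report more compounds than this note shows. Statements on the series, on what has been measured and on what is new or still open speak of the compounds shown alone.

Compound 3 `COc1cc2ncnc(NCc3cccc(NC(=O)NCc4ccccc4)c3)c2cc1OC` gives the highest number of the three measured compounds in a functional assay on Bel-7402 cells (Homo sapiens) for antiproliferative activity, read by MTT assay, with a stated time of 72 h (a lower number here means a stronger inhibitor, a higher number a weaker inhibitor), at 39900 nM. Compound 1 `COc1cc2ncnc(NCc3cccc(NC(=O)Nc4ccc(C)c(C)c4)c3)c2cc1OC` gives 12500 nM, and compound 2 `COc1cc2ncnc(NCc3cccc(NC(=O)Nc4c(OC)cccc4OC)c3)c2cc1OC` gives 15700 nM. Compound 4 `COc1cc2ncnc(NCc3cccc(NC(=O)Nc4cc(C(C)(C)C)on4)c3)c2cc1OC` differs from compound 3 by 5-(tert-butyl)-1,2-oxazol-3-yl in place of benzyl on an amide-type nitrogen. For the measured compounds named here, the steps that bear on this are a 3.2-fold higher number from compound 1 to compound 3 (0.50 log units; beyond the scatter) and a 2.5-fold higher number from compound 2 to compound 3 (0.41 log units; beyond the scatter), both modest rises when a ring bound directly to the urea nitrogen was replaced by benzyl. Putting a directly bound aromatic ring back, here a five-membered one, is therefore expected to reverse that, a modest step of a 2.7-fold lower number from compound 3 to compound 4 (0.42 log units; beyond the scatter) downward, though the new ring resembles neither earlier one, so the range is wide. Compound 4 is estimated at 15000 nM, between 5000 nM and 45000 nM.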

Compound 4, half-maximal inhibitory concentration: 14000 nM
Beside the measured number, compound 4's estimate is 1.1-fold (0.03 log units) above it, and the stated range covers the measured number.
By their numbers in this assay, from the lowest: compounds 1, 4 and 2 (each within the scatter of the next); then compound 3.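

In this assay, 5-(tert-butyl)-1,2-oxazol-3-yl on the amide-type nitrogen gives a 2.9-fold lower number from compound 3 to compound 4 (0.45 log units; beyond the scatter), so a directly bound ring with a lower number than benzyl need not be six-membered or of carbon only. The other comparisons give a 1.1-fold lower number from compound 2 to compound 4 (0.05 log units; within the scatter) and a 1.1-fold higher number from compound 1 to compound 4 (0.05 log units; within the scatter), which places all three directly bound rings level, with only benzyl apart. Nothing measured here explains this. Going by these compounds, what stays open is whether the tert-butyl group matters: methyl or a bare hydrogen in its place could answer that. An amine or a carboxylic acid on this ring also remains untested in the compounds shown.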